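Methyl in Place of Chloro on the Anilino Ring

This account rests on a few compounds, and the source may have more. Where it says the series, first, only, none or still open, it means among the compounds named here.

Measured compounds:
compound 1, `Cc1ccc(NCc2cn(-c3ccccc3)nc2-c2ccc(Br)cc2)cc1`, gives > 100000 nM in an ADME assay on MDBK cells (Bos taurus) for cytotoxicity, read by MTT assay, with a stated time of 72 h; a lower number here means that less compound is tolerated, a higher number that more compound is tolerated
compound 2, `FC(F)(F)c1ccc(NCc2cn(-c3ccccc3)nc2-c2ccccc2)cc1`, gives 34000 nM in this assay
compound 3, `Clc1ccc(NCc2cn(-c3ccccc3)nc2-c2ccccc2)cc1`, gives > 100000 nM in this assay

Compound 3 stands at a limit of the assay, not a number, and shares that limit with another of the three measured compounds (the limit of > 100000 nM in this assay, at which 2 of the 3 values shown sit). For the measured compounds named here, the only measured step, an at least 2.9-fold higher number from compound 2 to compound 3 (0.46 log units; beyond the scatter), shows that swapping a halogen for trifluoromethyl moved the value at least modestly upward. Compound 4, `Cc1ccc(NCc2cn(-c3ccccc3)nc2-c2ccccc2)cc1`, differs from compound 3 by methyl in place of chloro on an aromatic carbon. Going by the values given here, no measured step covers methyl replacing chloro, so no step beyond the scatter is expected; compound 1, which also carries a methyl group, likewise sits at the limit. Compound 4 is therefore expected to give 120000 nM, between 50000 nM and 300000 nM, a step that the limit leaves unreadable from compound 3 to compound 4.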

Compound 4, half-maximal cytotoxic concentration: > 100000 nM
Compound 4 gave a limit, no number; the forecaster's own chance of this, stated with the estimate: 75%; the middle value does not contradict the limit.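

For the compounds shown here, at this position on the anilino ring, methyl in place of trifluoromethyl gives an at least 2.9-fold higher number from compound 2 to compound 4 (0.46 log units; beyond the scatter) in this assay, so trifluoromethyl remains the only group here with a readable number. Compound 4 itself sits at a limit of the assay, not at a number: the limit of > 100000 nM in this assay, at which 3 of the 4 values shown sit. The steps to compound 4 from compound 3 and from compound 1 cannot be read, as both ends of each are limits. From the compounds shown here alone, whether methyl and chloro differ at all at this position stays open. So does how a methoxy group or a carboxylic acid here would read in this assay.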